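Series notes: chain substituent change on the shared core

The compounds below may be only part of what the source reports. "The series", "measured", "known", "first", "only" and "open" are said of these compounds alone.

Among the compounds with values here, compound 1 `CCn1c(=O)n(C2OC(CO)[C@@H](O)[C@H]2O)c2nc(N)nc(O)c21` is one of three compounds measured in a functional assay on the whole organism (B cells) with Mus musculus as the target; a higher number here means a larger maximal response, a lower number a smaller maximal response. In this assay compound 1 gives 82%, the second highest of the three numbers. Compound 3 `CCCn1c(=O)n(C2OC(COP(=O)(O)O)[C@@H](O)[C@H]2O)c2nc(N)nc(O)c21` gives 76%, a value within the scatter of compound 1. Compound 2 `CCCn1c(=O)n(C2C=CC(CO)O2)c2nc(N)nc(O)c21` gives 118%, beyond the scatter above compound 1. Compound 4 `Nc1nc(O)c2c(n1)n(C1OC(CO)[C@@H](O)[C@H]1O)c(=O)n2C/C=C/c1ccccc1` has not been measured; it differs from compound 1 by 2-phenylethenyl in place of methyl on a saturated chain carbon bound to an aromatic nitrogen. Within the data shown here, no measured step of this kind exists, and the two other compounds show no common direction for a change at this position. A small step is expected, with no firm direction beyond the scatter: the expected step of a number 8 percentage points higher from compound 1 to compound 4 (within the scatter) is modest. Compound 4 is expected to give 90%, estimated between 60% and 125%.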

Compound 4, largest response reached (reported as maximal response), in percent of the reference or control that the assay uses: 73%
Estimate against measurement, compound 4: 17 percentage points above, and the stated range covers the measured number.
By their numbers in this assay, from the lowest: compounds 4, 3 and 1 (each within the scatter of the next); then compound 2.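

In this assay, within the data shown here, the first measured step at this position is a number 9 percentage points lower from compound 1 to compound 4 (within the scatter). A saturated chain carbon bound to an aromatic nitrogen therefore carries 2-phenylethenyl, with its six-membered aromatic ring and double bond, in place of methyl without a change beyond the scatter. No available evidence accounts for this result.

From the compounds shown here alone, whether an amine or a carboxylic acid at this place would move the response beyond the scatter remains open. So does whether 2-phenylethenyl gives the same result on the rest of compound 2.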